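From bromo to iodo: a single halogen swap

The source may hold more compounds than are shown below. What is called first, only, known or untested is meant among the compounds shown, and "the series" means these compounds.

Compound 1 `Cc1ccc(NC(=O)/C=C/c2ccccc2)c(C(N)=O)c1` gives "not determined" (no result reported) 
Compound 2 `NC(=O)c1cc(Br)ccc1NC(=O)/C=C/c1ccccc1` gives 444 nM 

Among the measured compounds shown here, in a functional assay on RXF 393 cells (Homo sapiens) for inhibition, read by sulforhodamine B assay, with a stated time of 48 h (on this read-out lower numbers stand for stronger inhibition of growth and higher numbers for weaker inhibition of growth), compound 2 is the only compound with a number, so it has no rank yet. Compound 3 `NC(=O)c1cc(I)ccc1NC(=O)/C=C/c1ccccc1` differs from it in one place, (iodo in place of bromo on an aromatic carbon), with iodo in place of bromo on an aromatic carbon. For the measured compounds named here, no measured step shows how this place responds. With compound 2 at 444 nM as the only anchor, no change beyond the usual scatter is expected, in either direction. The expected step is a 1.1-fold lower number from compound 2 to compound 3 (0.02 log units; within the scatter) and nothing larger. For compound 3 the estimated value is 420 nM with an expected range from 170 nM to 1000 nM around that estimate.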

Compound 3, concentration for 50% growth inhibition: 3020 nM
Compound 3: the middle estimate sits 7.2-fold (0.86 log units) below what was measured; the whole stated range lies below it.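

In this assay, the position para to a large group proves sensitive to the choice of halogen: swapping one halogen atom for another gives a 6.8-fold higher number from compound 2 to compound 3 (0.83 log units; beyond the scatter). Within this single pair, bromo therefore gives stronger growth inhibition than iodo, although the two groups have the same heavy-atom, hydrogen-bond donor and acceptor counts and no net charge. The data shown offer no measured explanation for this loss. Still open, on these data alone, is how a smaller halogen such as chloro, or an amine, would behave here. As far as these compounds go, whether this trend extends beyond these two halogens also remains unknown.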